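The compounds below may be only part of what the source reports. "The series", "measured", "known", "first", "only" and "open" are said of these compounds alone.

Working notes on the series sharing the core of compound 1 `Cc1c(C)c2c(c(C)c1O)CC[C@@](C)(CC[N+](C)(C)C)O2`. In a functional assay (brain) for inhibition, with Rattus norvegicus as the target (a higher number here means a weaker inhibitor, a lower number a stronger inhibitor), compound 1 gives 2300 nM. Compound 3 `Cc1c(C)c2c(c(C)c1O)CCC(C)(CC[N+](C)(C)C)O2` gives 2600 nM in this assay, and the pair sits within the scatter, a 1.1-fold higher number from compound 1 to compound 3 (0.05 log units; within the scatter); the only difference between them is the configuration at the saturated ring carbon (the fact that one of compounds 1 and 3 is drawn with a defined configuration and the other without, at the place where they differ). Compound 2 `Cc1c(C)c2c(c(C)c1O)CC[C@@](C)(CC(=O)[N-][N+](C)(C)C)O2` gives 9000 nM in this assay, the highest number of the three measured, separated from both neighbours by more than the scatter.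

The step under consideration is from compound 2 to compound 4 `Cc1c(C)c2c(c(C)c1O)CC[C@@](C)(CCN(C)C)O2`: a group of 4 heavy atoms (3 carbon, 1 nitrogen; no ring) in place of a group of 7 heavy atoms (4 carbon, 2 nitrogen, 1 oxygen; no ring), on a saturated chain carbon bound to a saturated ring carbon. Among the measured compounds shown here, the one measured step that bears on it is a 3.9-fold higher number from compound 1 to compound 2 (0.59 log units; beyond the scatter), where the group of 7 heavy atoms entered in place of the group of 5 heavy atoms at the same position and the number rose by a modest amount. Compound 4 reverses that exchange, though with a group of 4 heavy atoms and no net charge rather than the group of 5. The expectation for compound 4 in this assay is therefore a drop of roughly the same size, a 3.6-fold lower number from compound 2 to compound 4 (0.56 log units; beyond the scatter), with an estimate of 2500 nM and a range from 1000 nM to 6500 nM.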

Compound 4, half-maximal inhibitory concentration: 1000 nM
For compound 4 the middle estimate is 2.5-fold (0.40 log units) above the measured one; the measured number falls inside the stated range.
By their numbers in this assay, from the lowest: compound 4; then compounds 1 and 3 (each within the scatter of the next); then compound 2.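

The exchange at this place can move the number well down as well as up: a 9.0-fold lower number from compound 2 to compound 4 (0.95 log units; beyond the scatter). Among the compounds shown here, compound 4 also goes past compound 1, with a 2.3-fold lower number from compound 1 to compound 4 (0.36 log units; beyond the scatter), so the group of compound 1 was not the best of those seen here, as the earlier compounds could not show. Across compounds 4, 1 and 2, the number rises as the group on the saturated chain carbon grows, with none of these three against that order, though three groups make a thin pattern. Nothing at hand bears on what lies behind these two steps.

Open, as far as these compounds go, is whether a primary amine, a carboxylic acid or a longer chain at this place would fall in the same order. Also open, from the compounds shown here alone, is whether the order holds for the other configuration at the saturated ring carbon, since only compound 1 has a counterpart in compound 3.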